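Adding a hydroxy to the seven-membered ring

A few compounds are considered here, and "the series" means these few. Any claim that something is new, unique, unknown or untested is made for them only; others in the source may bear on it.

Measured so far:
compound 1, `C=C1C(=O)O[C@@H]2[C@@H]1CC[C@H](C)[C@@](O)(C(=O)/C=C/C)[C@H]2OC(=O)/C(C)=C\C`: 0.4 ug/mL
compound 2, `C=C1C(=O)O[C@@H]2[C@@H]1C[C@@H](O)[C@H](C)[C@@](O)(C(=O)/C=C/C)[C@H]2OC(=O)/C(C)=C\C`: 1.1 ug/mL
compound 3, `C=C1C(=O)O[C@@H]2[C@@H]1CC[C@H](C)[C@@](O)(C(=O)CC(C)OC)[C@H]2OC(=O)C(C)CC`: 4.4 ug/mL

These three compounds share one core and were tested in a functional assay on Lu1 cells (Homo sapiens) for cytotoxicity; on this read-out lower numbers stand for an effect already at smaller amounts and higher numbers for an effect only at larger amounts of compound. Among them compound 1 stands at the lowest number: compound 2 lies nearest, at a higher value, and compound 3 lies furthest, at the highest value of the set.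

Compound 4, `C=C1C(=O)O[C@@H]2[C@@H]1[C@@H](O)C[C@H](C)[C@@](O)(C(=O)/C=C/C)[C@H]2OC(=O)/C(C)=C\C`, is not yet measured. It differs from compound 1 in one place: hydroxy in place of hydrogen on a saturated ring carbon.

Going by the values given here, only one measured step bears on this change. From compound 1 to compound 2 a hydroxy also replaced a hydrogen on a saturated ring carbon of the same core, at another position, and the result was a 2.8-fold higher number from compound 1 to compound 2 (0.44 log units; beyond the scatter). The change from compound 1 to compound 4 is of the same kind, so a step of similar size and in the same direction is expected, that is, a modestly higher number in this assay. Among the compounds with values here, because the single guiding step a 2.8-fold higher number from compound 1 to compound 2 (0.44 log units; beyond the scatter) concerns a different position, the expectation for compound 4 carries real uncertainty.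

Compound 4 is therefore expected to give 1 ug/mL, with a likely range from 0.4 ug/mL to 2.5 ug/mL. This estimate corresponds to an expected step of a 2.5-fold higher number from compound 1 to compound 4 (0.40 log units; beyond the scatter).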

Compound 4, concentration for half-maximal effect: 2.3 ug/mL
The estimate for compound 4 lay 2.3-fold (0.36 log units) below the measured number; the range from low to high includes it.
By their numbers in this assay, from the lowest: compound 1; then compound 2; then compounds 4 and 3 (each within the scatter of the next).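

In this assay, putting a hydroxy in place of hydrogen on this saturated ring carbon of the seven-membered ring, next to the ring atom that bears a fused ring, gives a 5.8-fold higher number from compound 1 to compound 4 (0.76 log units; beyond the scatter). The earlier compounds shown here showed this kind of change at only one place, as a 2.8-fold higher number from compound 1 to compound 2 (0.44 log units; beyond the scatter); now two carbons of this ring show it, and the number rises at both, with neither compound going against that direction. No measurement shown here explains why the number rises at either carbon.

As far as these compounds go, what remains open is whether the rise belongs to the hydroxy itself or would also appear with another group on this same carbon, such as a methoxy, an amine or a fluorine. Also open, from the compounds shown here alone, is whether the same hydroxy would give a step of this kind on the core of compound 3, which carries a different side chain and ester, and whether a hydroxy on the opposite face of this carbon would behave in the same way.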